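This account rests on a few compounds, and the source may have more. Where it says the series, first, only, none or still open, it means among the compounds named here.

Working notes on the series.

For the measured compounds named here, compound 1 `CCCCc1ccc(C[C@H]2COC(=O)[C@@H]2Cc2ccc(Cl)c(Cl)c2)cc1` is the first reference point; in a functional assay on HL-60 cells (Homo sapiens) for cytotoxicity, read by WST assay, with a stated time of 48 h (a lower number here means that less compound is needed, a higher number that more compound is needed for the effect), compound 1 gives 9400 nM. Compound 2 `O=C1OC[C@H](Cc2ccc(F)cc2)[C@H]1Cc1ccc(Cl)c(Cl)c1` carries the change (fluoro in place of butyl on an aromatic carbon), and in this assay compound 2 gives 14000 nM. The resulting step, a 1.5-fold higher number from compound 1 to compound 2 (0.17 log units; within the scatter), lies within the scatter, so the two values are read as one level rather than as a difference.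

Compound 3 `CCCCc1ccc(C[C@H]2COC[C@@H]2Cc2ccc(Cl)c(Cl)c2)cc1` has a different core from compound 1; the difference between the two cores is not broken down here. In this assay, going by the values given here, compound 3 gives 23000 nM, the highest of the three numbers so far, beyond the scatter against compound 1 and within the scatter against compound 2.

Compound 4 `Fc1ccc(C[C@H]2COC[C@@H]2Cc2ccc(Cl)c(Cl)c2)cc1` is not yet measured. It stands to compound 3 as compound 2 stands to compound 1: the change fluoro in place of butyl on an aromatic carbon is the same change, made at the same place, on the core of compound 3. Among the compounds with values here, the only guide is the single earlier instance, a 1.5-fold higher number from compound 1 to compound 2 (0.17 log units; within the scatter), which moved the number by an amount inside the scatter. Carried over to the core of compound 3, a step of about a 1.5-fold higher number from compound 3 to compound 4 (0.17 log units; within the scatter) is expected, resting on that one earlier step. Compound 4 is therefore estimated at 34000 nM in this assay, with a plausible range from 17000 nM to 70000 nM; the high end reflects that compound 3 already sits at the upper edge of the measured values and a further rise may approach the range where the assay reports only a limit.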

Compound 4, half-maximal effective concentration: 43000 nM
For compound 4 the middle estimate is 1.3-fold (0.10 log units) below the measured one, and the stated range covers the measured number.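

In this assay the change of butyl to fluoro on the core of compound 3 gives a 1.9-fold higher number from compound 3 to compound 4 (0.27 log units; within the scatter) and so, like the earlier step, does not separate the two compounds of the pair. Set side by side, the two steps agree, so within this small set the change carries from the core of compound 1 to the core of compound 3 without a difference that can be read: the same change on two cores in this assay, a 1.5-fold higher number (0.17 log units; within the scatter) from compound 1 to compound 2 and a 1.9-fold higher number (0.27 log units; within the scatter) from compound 3 to compound 4, 1.3-fold (0.10 log units) apart, within the scatter of two such steps. For the compounds shown here, this is a weak kind of transfer, however: it rests on only two pairs, neither step shows a real effect of the change on its own core, and agreement between two steps inside the scatter does not show that a larger effect would carry over in the same way, nor that the result holds on any further core or in any other assay.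

The compounds shown leave open whether another group at this place on the aromatic ring, such as an amine, a carboxylic acid or a longer chain, would move the number beyond the scatter on either core. They also leave open whether any such step would be the same size on the core of compound 1 and on the core of compound 3.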